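A few compounds are considered here, and "the series" means these few. Any claim that something is new, unique, unknown or untested is made for them only; others in the source may bear on it.

Measured in an ADME assay on BaF3 cells (Mus musculus) for cytotoxicity; on this read-out higher numbers stand for an effect only at larger amounts of compound and lower numbers for an effect already at smaller amounts:
Compound 1 `O=C(O)c1cc2c(Nc3ccc(OC(F)(F)F)cc3)ncnc2s1` gives > 10000 nM, a limit of this assay.
Compound 2 `CCn1ncc2c(Nc3ccc(OC(F)(F)F)cc3)ncnc21` gives > 10000 nM, a limit of this assay.
Compound 3 `NC(=O)c1cccc(Nc2cc(Nc3ccc(OC(F)(F)F)cc3)ncn2)c1` gives > 10000 nM, a limit of this assay.

Compound 2 therefore stands nowhere in particular among the numbers shown: only a limit is known for it, and the two further values are limits as well, (the limit of > 10000 nM in this assay, at which 3 of the 3 values shown sit). Within the data shown here, no step between measured compounds is available for comparison.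

Compound 4 `NC(=O)Cn1ncc2c(Nc3ccc(OC(F)(F)F)cc3)ncnc21` differs from compound 2 by carbamoyl in place of methyl on a saturated chain carbon bound to an aromatic nitrogen. Among the measured compounds shown here, with every value so far resting at the same limit, no direction can be read from the data, and the expected step from compound 2 to compound 4 is none beyond the scatter, a step that the limit leaves unreadable from compound 2 to compound 4. Compound 4 is accordingly estimated at 15000 nM, with a range from 5000 nM to 50000 nM, most likely again reported only as a limit.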

Compound 4, half-maximal effective concentration: 3300 nM
For compound 4 the middle estimate is 4.5-fold (0.66 log units) above the measured one; the whole stated range lies above it.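

In this assay, among these compounds, carbamoyl in place of methyl on a saturated chain carbon bound to an aromatic nitrogen gives an at least 3.0-fold lower number from compound 2 to compound 4 (0.48 log units; beyond the scatter), so this place on the shared core can move the read-out, which the earlier compounds could not show. Compound 4 is the only compound shown with a number rather than a limit. The step is only a lower bound because compound 2 rests at a limit: the limit of > 10000 nM in this assay, at which 3 of the 4 values shown sit.

From the compounds shown here alone, whether a carboxylic acid, an amine or a longer chain at this place would also lower the number stays open. So does how much of the step belongs to the carbonyl and how much to the amide nitrogen.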